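The source may report more compounds than this note shows. Statements on the series, on what has been measured and on what is new or still open speak of the compounds shown alone.

Measured in an ADME assay on ECV-304 cells (Homo sapiens) for cytotoxicity, read by MTT assay, with a stated time of 72 h; a higher number here means a weaker inhibitor, a lower number a stronger inhibitor:
- compound 1 `COc1ccc(C2=C(c3cc(OC)c(OC)c(OC)c3)C(=O)C(O)C2)cc1` gives < 1 ug/mL, a limit of the assay
- compound 2 `COc1ccc(C2=C(c3cc(OC)c(OC)c(OC)c3)C(=O)C(OC(C)=O)C2)cc1F` gives 41 ug/mL

Within the data shown here, compound 2 holds the only actual number in this assay, and it is the higher of the two values shown. The step to compound 3 `COc1ccc(C2=C(c3cc(OC)c(OC)c(OC)c3)C(=O)C(O)C2)cc1F` is hydrogen in place of acetyl on an oxygen on a saturated carbon, acetoxy to hydroxy. A fall in the number beyond the scatter, toward a stronger inhibitor, is expected, resting only on compound 1 with its limit of < 1 ug/mL. The estimated step is a 21-fold lower number from compound 2 to compound 3 (1.31 log units; beyond the scatter). The estimate for compound 3 is 2 ug/mL, with an expected range of 0.3 ug/mL to 20 ug/mL.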

Compound 3, half-maximal inhibitory concentration: 19.5 ug/mL
Beside the measured number, compound 3's estimate is 9.8-fold (0.99 log units) below it, and the stated range covers the measured number.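

In this assay, hydroxy in place of acetoxy, with the fluoro kept, is only a modest change: a 2.1-fold lower number from compound 2 to compound 3 (0.32 log units; beyond the scatter). The larger effect comes from fluoro in place of hydrogen on an aromatic carbon with the hydroxy kept: an at least 19-fold higher number from compound 1 to compound 3 (1.29 log units; beyond the scatter). That step has only a lower bound, since compound 1 carries a limit of the assay: the limit of < 1 ug/mL in this assay, at which 1 of the 3 values shown sits.

From the compounds shown here alone, the full size of the fluoro step remains open, as does its size with acetoxy in place. Also open, going by these compounds, is how chloro on that aromatic carbon, or a longer ester chain on the oxygen, would read.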